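A few compounds are considered here, and "the series" means these few. Any claim that something is new, unique, unknown or untested is made for them only; others in the source may bear on it.

Compound 3 `COc1ccc(-c2nn(-c3ccccc3)cc2C(=O)NC(=S)Nc2ccc(F)cc2)cc1` gives the lowest of the three numbers in a functional assay on A549 cells (Homo sapiens) for inhibition, read by CCK-8 assay, with a stated time of 48 h (on this read-out lower numbers stand for stronger inhibition and higher numbers for weaker inhibition), at 1430 nM, although compound 2 sits within the scatter of it. Compound 2 `Cc1ccc(NC(=S)NC(=O)c2cn(-c3ccccc3)nc2-c2ccc(C)cc2)cc1` gives 2830 nM. Compound 1 `Cc1ccc(-c2nn(-c3ccccc3)cc2C(=O)NC(=S)Nc2ccc(Cl)cc2)cc1` gives 3170 nM, a gap from compound 3 that is beyond the scatter. Within the data shown here, the one single-point step measured so far, a 1.1-fold lower number from compound 1 to compound 2 (0.05 log units; within the scatter), concerns methyl in place of chloro on an aromatic carbon. Compound 4 `Cc1ccc(-c2nn(-c3ccccc3)cc2C(=O)NC(=S)Nc2ccc(F)cc2)cc1` differs from compound 3 by methyl in place of methoxy on an aromatic carbon. Among the measured compounds shown here, no measured step covers methyl in place of methoxy at this place, and the step from compound 1 to compound 2 is at a different place, so it does not bear on it directly. What can be said is that compound 1 and compound 2 both carry 4-methylphenyl on the shared core and neither gives a number lower than compound 3, which carries 4-methoxyphenyl, though each also differs from compound 3 elsewhere. The expectation for compound 4 is a somewhat higher number, a 1.6-fold higher number from compound 3 to compound 4 (0.21 log units; within the scatter), a step that may fall within the scatter. For compound 4 the estimate is 2300 nM, with a range from 1000 nM to 5500 nM.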

Compound 4, half-maximal inhibitory concentration: 3420 nM
Compound 4: the middle estimate sits 1.5-fold (0.17 log units) below what was measured; the range from low to high includes it.
By their numbers in this assay, from the lowest: compounds 3, 2, 1 and 4 (each within the scatter of the next, the first and the last beyond it).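

Among these compounds, replacing 4-methoxyphenyl with 4-methylphenyl gives a 2.4-fold higher number from compound 3 to compound 4 (0.38 log units; beyond the scatter) in this assay, the first direct reading of this change, and it shows a modest step beyond the scatter in favour of methoxy. At the other end of the molecule, with 4-methylphenyl held fixed, a 1.2-fold higher number from compound 2 to compound 4 (0.08 log units; within the scatter) and a 1.1-fold higher number from compound 1 to compound 4 (0.03 log units; within the scatter) both lie within the scatter, so fluoro, chloro and methyl there cannot be told apart, and the methoxy-to-methyl change is the only single change shown that goes beyond the scatter. Nothing available explains this step.

Going by these compounds, the methoxy comparison rests on one pair with fluoro at the other end, so whether it holds with chloro or methyl there remains open. On these data alone, how a hydroxyl, an amine or a longer ether such as ethoxy would behave at this place is also open.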